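A few compounds are considered here, and "the series" means these few. Any claim that something is new, unique, unknown or untested is made for them only; others in the source may bear on it.

Compound 1 `O=C(Nc1ccc(-c2ccccn2)cc1)C1CCCN(Cc2ccc(F)c(F)c2)C1`: 9000 nM
Compound 2 `O=C(Nc1ccc(-c2nccs2)cc1)C1CCCN(Cc2ccc(F)c(F)c2)C1`: 240 nM

Within the data shown here, in a functional assay on A-375 cells (Homo sapiens) for antiproliferative activity (on this read-out lower numbers stand for stronger inhibition and higher numbers for weaker inhibition), compound 2 gives 240 nM, the lowest of the two numbers so far, and its only neighbour, compound 1, gives 9000 nM.

Compound 3 `O=C(Nc1ccc(-c2c[nH]cn2)cc1)C1CCCN(Cc2ccc(F)c(F)c2)C1` is still unmeasured. It differs from compound 2 as follows: 1H-imidazol-4-yl in place of 1,3-thiazol-2-yl on an aromatic carbon. In short, 1H-imidazol-4-yl replaces 1,3-thiazol-2-yl on an aromatic carbon, para to a large group.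

Among the measured compounds shown here, only one measured step bears on this, the large change a 38-fold lower number from compound 1 to compound 2 (1.57 log units; beyond the scatter), which is an exchange of groups at the same place. It suggests that this assay can respond strongly to the group here, so a change lying wholly within the scatter seems unlikely. For the measured compounds named here, no measured compound carries 1H-imidazol-4-yl, so direction and size rest on thin evidence. Going by the values given here, with compound 2 at the low end at 240 nM, a rise is the likelier outcome, probably smaller than the one measured step.

The expected step is a 5.0-fold higher number from compound 2 to compound 3 (0.70 log units; beyond the scatter). For compound 3 the estimated value is 1200 nM, with an expected range of 250 nM to 6000 nM.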

Compound 3, half-maximal inhibitory concentration: > 20000 nM
Compound 3: no number, only a limit; the forecaster's own chance of this, stated with the estimate: 7%; middle value at least 16-fold (1.22 log units) from the limit.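

In this assay, compound 3 has no number, only a limit: the limit of > 20000 nM in this assay, at which 1 of the 3 values shown sits.

Replacing 1,3-thiazol-2-yl with 1H-imidazol-4-yl gives an at least 83-fold higher number from compound 2 to compound 3 (1.92 log units; beyond the scatter), so this position separates two five-membered aromatic rings that each have 5 heavy atoms and 2 hetero atoms. The replacement of pyridin-2-yl with the same group gives an at least 2.2-fold higher number from compound 1 to compound 3 (0.34 log units; beyond the scatter), which places 1H-imidazol-4-yl on the weak side of both other groups and shows that a five-membered ring alone does not confer the low number of compound 2, with compound 3 as the case against that reading. Among the three compounds, compound 2, which carries 1,3-thiazol-2-yl on this aromatic carbon, gives the lowest number, 240 nM.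

The change from compound 2 to compound 3 exchanges sulfur for nitrogen and also adds a hydrogen-bond donor, and the compounds shown cannot separate these two differences. Going by these compounds, an oxazol-2-yl group would test the sulfur alone, and a 1-methylimidazol-4-yl group would test the donor hydrogen, while the true size of both steps stays open behind the limit.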